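A few compounds are considered here, and "the series" means these few. Any claim that something is new, unique, unknown or untested is made for them only; others in the source may bear on it.

Three compounds sharing one core were compared in an assay on isolated protein for binding affinity to leukotriene B4 receptor 1 (Homo sapiens), tested at 1 uM; on this read-out higher numbers stand for more inhibition at the one concentration tested (going by the name of the read-out) and lower numbers for less inhibition. Compound 1 `CCCc1cc(C(C)=O)c(O)cc1OCCCCC#N` gives 37%, compound 2 `C=CCc1cc(C(C)=O)c(O)cc1OCCCCC#N` gives 57% and compound 3 `C=CCc1cc(C(C)=O)c(O)cc1OCCCCC` gives 23%. Compound 2 stands highest of the three. The nearest number belongs to compound 1, and the step of a number 20 percentage points higher from compound 1 to compound 2 (beyond the scatter) goes with vinyl in place of ethyl on a saturated chain carbon bound to an aromatic carbon. The furthest number belongs to compound 3, reached by a number 34 percentage points lower from compound 2 to compound 3 (beyond the scatter) with methyl in place of cyano on a saturated chain carbon, four bonds along the chain from an oxygen on an aromatic ring.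

Compound 4 `C=CCc1cc(C(=O)c2ccccc2)c(O)cc1OCCCCC#N` differs from compound 2 in a third place: phenyl in place of methyl on a carbonyl carbon, on a carbonyl carbon whose other neighbour is an aromatic carbon, read one bond further out as acetyl to benzoyl. Among the measured compounds shown here, neither measured step touches the carbonyl substituent, so no measured step bears on this change; both were beyond the scatter but altered other parts of the molecule. The expected step of a number 7 percentage points lower from compound 2 to compound 4 (within the scatter) in this assay is therefore none beyond the scatter. The estimate for compound 4 is 50%, between 25% and 75%.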

Compound 4, a percentage reported as inhibition, at one concentration (the size of the read-out at that concentration, not a potency): 5%
Compound 4: the middle estimate sits 45 percentage points above what was measured; measured number below the stated range.
By their numbers in this assay, from the lowest: compound 4; then compound 3; then compound 1; then compound 2.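

Up to this point, the carbonyl substituent had stayed methyl in every compound, so nothing had tested this place. In this assay, acetyl to benzoyl brings a number 52 percentage points lower from compound 2 to compound 4 (beyond the scatter), which shows that the read-out responds strongly at the carbonyl carbon. The nitrile and the unsaturated chain that compound 2 carries are both still present in compound 4, yet they do not hold the number up once phenyl enters. No measurement shown here says why the number falls so far.

As far as these compounds go, with only methyl and phenyl on the carbonyl carbon, it remains open whether an ethyl, a cyclopropyl or a cyclohexyl there would keep the number of compound 2 or lose it as phenyl does. From the compounds shown here alone, it is equally open whether phenyl would have the same effect on the saturated chain of compound 1.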